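The compounds below may be only part of what the source reports. "The series", "measured", "known", "first", "only" and "open" are said of these compounds alone.

Measured in an ADME assay on PBMC cells (Homo sapiens) for cytotoxicity, read by MTT assay, with a stated time of 24 h; a lower number here means a stronger inhibitor, a higher number a weaker inhibitor:
- compound 1 `COc1cc(C)cc2c1C(=O)C=C(c1c(C)cc3c(c1OC)C(=O)C(Nc1ccc(Cl)cc1)=CC3=O)C2=O`: 44900 nM
- compound 2 `COc1cc(C)cc2c1C(=O)C=C(c1c(C)cc3c(c1OC)C(=O)C(Nc1ccc4ccccc4c1)=CC3=O)C2=O`: 73800 nM

In this assay, compound 2 gives 73800 nM, which lies within the scatter of compound 1 at 44900 nM. The next compound, compound 3 `COc1cc(C)cc2c1C(=O)C=C(c1c(C)cc3c(c1OC)C(=O)C(NCc1ccccc1)=CC3=O)C2=O`, has not yet been measured. It differs from compound 2 as follows: benzyl in place of naphthalen-2-yl on an amine nitrogen.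

Among the compounds with values here, only one measured step bears on this change, since it also exchanges the group on that nitrogen: a 1.6-fold higher number from compound 1 to compound 2 (0.22 log units; within the scatter). Neither measured compound carries benzyl, so this evidence is indirect. No step beyond the scatter is therefore expected, and no direction is favoured. The estimate means a 1.3-fold lower number from compound 2 to compound 3 (0.13 log units; within the scatter), an expected step. For compound 3 the estimated value is 55000 nM, with an expected range from 25000 nM to 110000 nM.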

Compound 3, half-maximal inhibitory concentration: > 100000 nM
Compound 3: no number, only a limit (the forecaster's own chance of this, stated with the estimate: 15%); at least 1.8-fold (0.25 log units) between middle value and limit.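

In this assay compound 3 gives > 100000 nM, which is a limit and not a number. On this amine nitrogen, the earlier exchange had produced no step beyond the scatter, but the read-out now shows an at least 2.2-fold higher number from compound 1 to compound 3 (0.34 log units; beyond the scatter), so the group at this position can separate compounds in this assay, at least for benzyl against 4-chlorophenyl. The exchange for naphthalen-2-yl reads an at least 1.3-fold higher number from compound 2 to compound 3 (0.13 log units; that floor lies within the scatter), so that comparison does not clear the scatter, and only compound 3 reaches the top of the range: the limit of > 100000 nM in this assay, at which 1 of the 3 values shown sits.

On these data alone, how far compound 3 lies past its limit remains open, and with it the true size of both steps. Also open, as far as these compounds go, is how an unsubstituted phenyl or a longer chain such as phenethyl on this nitrogen would read.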